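A few compounds are considered here, and "the series" means these few. Any claim that something is new, unique, unknown or untested is made for them only; others in the source may bear on it.

Working notes on the series. In a functional assay on MCF7 cells (Homo sapiens) for cytotoxicity, read by MTT assay, with a stated time of 48 h (on this read-out higher numbers stand for weaker inhibition and lower numbers for stronger inhibition), compound 1 `CC(=NNC(=S)Nc1ccccc1)c1ccccn1`, which has hydrogen where the others carry a halogen, gives 0.18 nM. Compound 3 `CC(=NNC(=S)Nc1ccc(I)cc1)c1ccccn1` gives 6.6 nM and compound 2 `C/C(=N/NC(=S)Nc1ccc(Cl)cc1)c1ccccn1` gives 8.49 nM. These two values lie within the scatter of each other, and both sit far above the number for compound 1.

Compound 4 `CC(=NNC(=S)Nc1ccc(Cl)cc1)c1ccccn1` follows from compound 3 by chloro in place of iodo on an aromatic carbon, with chloro in place of iodo on an aromatic carbon, para to a large group. Going by the values given here, the one measured step at this place is a 37-fold higher number from compound 1 to compound 3 (1.56 log units; beyond the scatter), large and beyond the scatter, with iodo in place of hydrogen. That step compares a halogen with hydrogen and says nothing directly about chloro against iodo.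

Compound 2 bears more closely on the question. It carries chloro in the same place and has its double-bond geometry drawn where compound 4 leaves it open. Compound 2 stands at 8.49 nM. An exchange of one halogen for the other is therefore not expected to move this assay beyond the scatter. The expected step is a 1.2-fold higher number from compound 3 to compound 4 (0.08 log units; within the scatter), towards a slightly higher number at most. For compound 4 the estimated value is 8 nM, with an expected range of 3.5 nM to 18 nM.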

Compound 4, half-maximal inhibitory concentration: 8.5 nM
Estimate against measurement, compound 4: 1.1-fold (0.03 log units) below; measured number inside the range.
By their numbers in this assay, from the lowest: compound 1; then compounds 3, 2 and 4 (each within the scatter of the next).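

In this assay the exchange of iodo for chloro on an aromatic carbon, para to a large group, now has a direct reading in a 1.3-fold higher number from compound 3 to compound 4 (0.11 log units; within the scatter) and so the two halogens cannot be told apart at this position. Chloro also parts from hydrogen, with a 47-fold higher number from compound 1 to compound 4 (1.67 log units; beyond the scatter) standing alongside a 37-fold higher number from compound 1 to compound 3 (1.56 log units; beyond the scatter) for iodo, so both halogens shown give a much higher number than the hydrogen of compound 1. The step of a 1.0-fold higher number from compound 2 to compound 4 (0.00 log units; within the scatter) gives no reading of the double-bond geometry, because the comparison rests only on how the two structures are drawn: the fact that one of compounds 2 and 4 is drawn with a defined configuration and the other without, at the place where they differ.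

The compounds shown leave open whether fluoro, a methoxy group, an amine or a carboxylic acid in this place would read with the halogens or with the hydrogen of compound 1 in this assay. They also leave open whether a double bond of defined opposite geometry would read the same as compound 2, and whether a chloro group on another carbon of this ring would keep the number of compound 4.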